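The source may hold more compounds than are shown below. What is called first, only, known or untested is meant among the compounds shown, and "the series" means these compounds.

Compound 3 `COc1ccc(C2CC(=O)c3ccc(C)cc3O2)cc1` gives 3350 nM in an in vitro assay on BTI-TN-5B1-4 cells for inhibition of Amine oxidase [flavin-containing] B (Homo sapiens); a higher number here means a weaker inhibitor, a lower number a stronger inhibitor. Compound 1 `Cc1ccc(C2CC(=O)c3ccc(C)cc3O2)cc1` differs from it by one change, (methyl in place of methoxy on an aromatic carbon), and in this assay compound 1 gives 500 nM; that single change produced a 6.7-fold lower number from compound 3 to compound 1 (0.83 log units; beyond the scatter). Compound 2 `COc1ccc(-c2cc(=O)c3ccc(F)cc3o2)cc1` is built on a different core; how its core differs from the core of compound 3 is not broken down here. In this assay compound 2 gives 1340 nM, a number that sits between the values of compound 3 and compound 1.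

Compound 4 `Cc1ccc(-c2cc(=O)c3ccc(F)cc3o2)cc1` is compound 2 carrying (methyl in place of methoxy on an aromatic carbon), the same change, at the same kind of place, that turned compound 3 into compound 1. Among the compounds with values here, whether the change acts alike on the second core cannot be known until compound 4 is measured; the one earlier example is the only guide. A step of about a 5.4-fold lower number from compound 2 to compound 4 (0.73 log units; beyond the scatter) is expected, resting on the earlier 6.7-fold lower number from compound 3 to compound 1 (0.83 log units; beyond the scatter). Compound 4 is therefore estimated to give 250 nM in this assay, most likely somewhere between 90 nM and 700 nM.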

Compound 4, half-maximal inhibitory concentration: 4330 nM
For compound 4 the middle estimate is 17-fold (1.24 log units) below the measured one; measured number outside the range, above it.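

Replacing methoxy with methyl on the core of compound 2 gave a 3.2-fold higher number from compound 2 to compound 4 (0.51 log units; beyond the scatter), so in this assay the number rose, whereas the same change lowered it on the core of compound 3. The two results are far enough apart to count as a real difference, which shows that the effect of this change did not carry over from one core to the other in this series: the same change on two cores in this assay, a 6.7-fold lower number (0.83 log units; beyond the scatter) from compound 3 to compound 1 and a 3.2-fold higher number (0.51 log units; beyond the scatter) from compound 2 to compound 4, 22-fold (1.34 log units) apart, beyond the scatter of two such steps. Within the data shown here, this does not show why the direction reverses or which feature of the cores is responsible, and with only two cores, it gives no rule for predicting the result on a third.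

The compounds shown carry only methoxy or methyl at this place, so it remains open how a chlorine, a hydroxyl or an amine there would behave on either core. Also open, as far as these compounds go, is which part of the core sets the direction, a question that would need compounds whose cores differ from each other in only one place.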